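The compounds below may be only part of what the source reports. "The series", "measured", "known", "first", "only" and "open" are said of these compounds alone.

Measured so far in a functional assay on HepG2 cells for inhibition of squalene monooxygenase (Homo sapiens); a higher number here means a weaker inhibitor, a lower number a stronger inhibitor:
compound 1 `CCN(C/C=C/C#CC(C)(C)C)Cc1cccc(OCCN(C)S(=O)(=O)c2ccsc2)c1`: 250 nM
compound 2 `CCN(C/C=C/C#CC(C)(C)C)Cc1cccc(OCCN(C)S(=O)(=O)c2cc3ccccc3s2)c1`: 1800 nM

Compound 1 stands at the lower of the two numbers; the only other, compound 2, sits a 7.2-fold higher number from compound 1 to compound 2 (0.86 log units; beyond the scatter) away. The untested compound 3 `CCN(C/C=C/C#CC(C)(C)C)Cc1cccc(OCCN(CC)S(=O)(=O)c2cccs2)c1` differs from compound 1 by a group of 11 heavy atoms (6 carbon, 1 nitrogen, 2 oxygen, 2 sulfur; one five-membered aromatic ring with 1 hetero atom) in place of a group of 10 heavy atoms (5 carbon, 1 nitrogen, 2 oxygen, 2 sulfur; one five-membered aromatic ring with 1 hetero atom), on a saturated chain carbon, two bonds along the chain from an oxygen on an aromatic ring, so the ethyl((thiophen-2-yl)sulfonyl)amino group enters. Within the data shown here, no measured step matches this change; the one step available, from compound 1 to compound 2, concerns a larger ring system on the sulfonyl sulfur and is of modest size. With the five-membered ring kept, compound 3 is expected to stay close to compound 1, the estimated step being a 1.3-fold higher number from compound 1 to compound 3 (0.11 log units; within the scatter). The estimate for compound 3 is 320 nM, between 120 nM and 850 nM.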

Compound 3, half-maximal inhibitory concentration: 90 nM
The estimate for compound 3 lay 3.6-fold (0.55 log units) above the measured number; the whole stated range lies above it.
By their numbers in this assay, from the lowest: compound 3; then compound 1; then compound 2.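

In this assay there is a 2.8-fold lower number from compound 1 to compound 3 (0.44 log units; beyond the scatter) as the ethyl((thiophen-2-yl)sulfonyl)amino group enters, so this place on the saturated chain carbon allows a lower number than compound 1 gives, whereas the earlier step on the sulfonyl sulfur went upward. The step changes the thiophene attachment and the nitrogen substituent together, and these compounds cannot separate the two. Nothing available explains the lower number.

Open, from the compounds shown here alone, is which of the two changes carries the step. Also open, going by these compounds, is how a propyl on the sulfonamide nitrogen, or a phenyl on the sulfonyl sulfur, would read.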